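The source may hold more compounds than are shown below. What is called first, only, known or untested is meant among the compounds shown, and "the series" means these compounds.

Working notes on the series. Compound 1 `Cc1ccc(-c2cc(/N=C/N(C)C)n(-c3ccc(Br)cc3)n2)cc1` was run in a functional assay on NPC-TW01 cells (Homo sapiens) for inhibition, read by MTT assay, with a stated time of 72 h; on this read-out lower numbers stand for stronger inhibition of growth and higher numbers for weaker inhibition of growth; for compound 1 the assay reports only a limit, > 100000 nM. Compound 2 `CN(C)/C=N/c1cc(-c2ccc(Cl)cc2)nn1-c1ccc(Br)cc1` gives 60700 nM in this assay. Compound 2 differs from compound 1 by chloro in place of methyl on an aromatic carbon, and the measured step is an at least 1.6-fold lower number from compound 1 to compound 2 (0.21 log units; that floor lies within the scatter), which has to be read against (the limit of > 100000 nM in this assay, at which 1 of the 3 values shown sits). Compound 3 `Cc1ccc(-c2nn(-c3ccc(Br)cc3)c(N)c2C=O)cc1` gives 28200 nM in this assay. The difference between the core of compound 1 and the core of compound 3 is not broken down here. Compound 4 `Nc1c(C=O)c(-c2ccc(Cl)cc2)nn1-c1ccc(Br)cc1` is not yet measured. It differs from compound 3 by chloro in place of methyl on an aromatic carbon, the same change already made from compound 1 to compound 2. The step expected for compound 4 is a 1.6-fold lower number from compound 3 to compound 4 (0.19 log units; within the scatter), resting on an at least 1.6-fold lower number from compound 1 to compound 2 (0.21 log units; that floor lies within the scatter), whose floor lies within the scatter. Compound 4 is therefore estimated at 18000 nM, between 7000 nM and 50000 nM.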

Compound 4, concentration for 50% growth inhibition: 59700 nM
Estimate against measurement, compound 4: 3.3-fold (0.52 log units) below; measured number outside the range, above it.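

In this assay, 4-methylphenyl to 4-chlorophenyl gives a 2.1-fold higher number from compound 3 to compound 4 (0.33 log units; beyond the scatter), so on these two cores the change does not carry over as one step: the same change on two cores in this assay, an at least 1.6-fold lower number (0.21 log units; that floor lies within the scatter) from compound 1 to compound 2 and a 2.1-fold higher number (0.33 log units; beyond the scatter) from compound 3 to compound 4, at least 3.4-fold (0.54 log units) apart, beyond the scatter of two such steps. Compound 1 gives > 100000 nM, which is a limit and not a number, so the earlier step is known only as a floor: the limit of > 100000 nM in this assay, at which 1 of the 4 values shown sits. The two cores show that the step depends on the core in this pair of pairs, but not which feature of the core matters or how the change would read on a further core.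

Open, from the compounds shown here alone, is whether a methoxy group in place of the methyl or chloro would follow either step. Also open, going by these compounds, is how the same change would read with a carboxylic acid in place of the carbonyl group of compound 3.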